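The source may hold more compounds than are shown below. What is called first, only, known or untested is meant among the compounds shown, and "the series" means these compounds.

Series notes. Compound 1 `Cn1c(Cc2nn(C)c(=O)c3ccccc23)nnc1SCCCCCCCC(=O)Nc1ccc(Cl)cc1Cl` carries a seven-carbon linker between the thioether and the dichloroanilide. Going by the values given here, in an assay on 32D cells for inhibition of interleukin-15 (Mus musculus), read by resazurin assay, with stated times of 30 min and 2.5 days, in the presence of a further agent that is not named here (a lower number here means a stronger inhibitor, a higher number a weaker inhibitor), compound 1 gives 2200 nM, the lowest of the two numbers so far. Compound 2 `Cn1nc(Cc2nnc(SCC(=O)Nc3ccc(Cl)cc3Cl)n2CCC=O)c2ccccc2c1=O` differs from it in several places at once; in this assay compound 2 gives 6000 nM, which stands above compound 1 by more than the scatter, so compound 1 is the reference point for the next step. Compound 3 `CN(C)CCCn1c(Cc2nn(C)c(=O)c3ccccc23)nnc1SCCCCCCCC(=O)Nc1ccc(Cl)cc1Cl` is the next entry, awaiting measurement in this assay. It differs from compound 1 only in the change (2-(dimethylamino)ethyl in place of hydrogen on a saturated chain carbon bound to an aromatic nitrogen). Among the compounds with values here, no pair of measured compounds yet shows what such a change does here, so the expected step is small and of uncertain sign, within or just beyond the scatter. On that basis the step from compound 1 to compound 3 is expected to be a 1.5-fold lower number from compound 1 to compound 3 (0.17 log units; within the scatter). Compound 3 is estimated at 1500 nM, with a range from 400 nM to 5000 nM.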

Compound 3, half-maximal inhibitory concentration: 3700 nM
For compound 3 the middle estimate is 2.5-fold (0.39 log units) below the measured one, within the range that was stated.
By their numbers in this assay, from the lowest: compounds 1, 3 and 2 (each within the scatter of the next, the first and the last beyond it).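

The position on the saturated chain carbon bound to an aromatic nitrogen accepts 2-(dimethylamino)ethyl in place of hydrogen without a change beyond the scatter: in this assay the step is a 1.7-fold higher number from compound 1 to compound 3 (0.23 log units; within the scatter). Going by these compounds alone, this is the first single-place change, and it shows that, on the core and seven-carbon linker of compound 1, the same difference read as methyl to 3-(dimethylamino)propyl leaves the two compounds indistinguishable. Nothing available explains this result.

Going by these compounds, whether this tolerance extends to a carboxylic acid, a morpholine or a longer alkyl chain at this position remains open. Compound 2 differs from compound 1 in several places at once, so the contribution of its own group at this position cannot be read.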